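The source may report more compounds than this note shows. Statements on the series, on what has been measured and on what is new or still open speak of the compounds shown alone.

In a functional assay on LS174T cells (Homo sapiens) for antiproliferative activity (a higher number here means a weaker inhibitor, a lower number a stronger inhibitor), compound 1 (`CNc1ccc(/C=C/c2c(F)cccc2F)cn1`) gives 30.1 nM and compound 2 (`CCNc1ccc(/C=C/c2c(F)cccc2F)cn1`) gives 31.3 nM, so the two stand level within the scatter. Compound 3 (`CNc1ccc(/C=C/c2c(F)cccc2Cl)cn1`) differs from compound 1 by one change (chloro in place of fluoro on an aromatic carbon): chloro in place of fluoro on an aromatic carbon. Within the data shown here, the only measured step (a 1.0-fold higher number from compound 1 to compound 2 (0.02 log units; within the scatter)) lies on the saturated chain carbon bound to a nitrogen, so it does not test this change. Among the measured compounds shown here, no measured step covers this swap, so no shift beyond the scatter is expected in this assay, and no direction can be assigned. For compound 3 the estimated value is 35 nM (range 14 nM to 90 nM), an expected step (a 1.2-fold higher number from compound 1 to compound 3 (0.07 log units; within the scatter)).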

Compound 3, half-maximal inhibitory concentration: 4 nM
Compound 3: the middle estimate sits 8.8-fold (0.94 log units) above what was measured; the measured number lies below the stated range.
By their numbers in this assay, from the lowest: compound 3; then compounds 1 and 2 (each within the scatter of the next).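

In this assay, among these compounds, chloro in place of fluoro on an aromatic carbon gives a clear shift (a 7.5-fold lower number from compound 1 to compound 3 (0.88 log units; beyond the scatter)), whereas the only earlier step, on the saturated chain carbon (a 1.0-fold higher number from compound 1 to compound 2 (0.02 log units; within the scatter)), stayed within the scatter. This aromatic carbon, ortho to a large group and meta to a fluoro group, therefore responds to which halogen it carries, at least in this single pair. No available evidence accounts for the shift.

Left open is whether bromo, methyl or methoxy at this position would lower the number further or reverse the shift. Also open, from the compounds shown here alone, is whether chloro in place of the remaining fluoro group, or the same swap on the core of compound 2, would shift the number as well.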